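The compounds below may be only part of what the source reports. "The series", "measured", "known", "first", "only" and "open" are said of these compounds alone.

Compound 1 `CCCCN(CC)c1nc(C)nc2c1n(C)c(=O)n2-c1c(C)cc(C)cc1C` and compound 2 `CCCN(CC1CC1)c1nc(C)nc2c1n(C)c(=O)n2-c1c(C)cc(C)cc1C` share one core and differ only in the amino group on an aromatic carbon. In an assay on HEK293 cells for binding affinity to corticotropin-releasing factor receptor 1 (Homo sapiens), read by radioligand binding (on this read-out higher numbers stand for weaker inhibition and lower numbers for stronger inhibition), compound 1 gives 4.4 nM, and in the same assay compound 2 gives 6.1 nM. Compound 2 carries the higher of the two numbers, but the step of a 1.4-fold higher number from compound 1 to compound 2 (0.14 log units; within the scatter) stays within the scatter, so the two compounds cannot be ordered on these data.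

Compound 3 `CCCN(CC1CC1)c1nc(C)nc2c1n(C)c(=O)n2-c1c(C)cc(C)nc1C` is not yet measured. It keeps the (cyclopropylmethyl)(propyl)amino group of compound 2 and alters the ring on the aromatic nitrogen: 2,4,6-trimethylpyridin-3-yl in place of 2,4,6-trimethylphenyl on an aromatic nitrogen. Going by the values given here, none of the measured steps touches this position; the only measured step, a 1.4-fold higher number from compound 1 to compound 2 (0.14 log units; within the scatter), concerns the amino group and says nothing about the ring on the aromatic nitrogen. No direction can be derived from the series for the step in this assay, and the working expectation is a change that does not exceed the scatter, with a wide range to cover the unknown. Compound 3 is therefore estimated to give 9 nM, between 3 nM and 30 nM. The estimated step of a 1.5-fold higher number from compound 2 to compound 3 (0.17 log units; within the scatter) is expected to lie within the scatter.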

Compound 3, inhibition constant: 113 nM
For compound 3 the middle estimate is 13-fold (1.10 log units) below the measured one; measured number outside the range, above it.
By their numbers in this assay, from the lowest: compounds 1 and 2 (each within the scatter of the next); then compound 3.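

Going by these compounds alone, the ring on the aromatic nitrogen is the first position where a single change moves the number beyond the scatter: in this assay, 2,4,6-trimethylpyridin-3-yl in place of 2,4,6-trimethylphenyl gives a 19-fold higher number from compound 2 to compound 3 (1.27 log units; beyond the scatter), a large step towards weaker inhibition. The heavy-atom count stays at 9 and the change amounts to one ring carbon exchanged for nitrogen, which adds 1 hydrogen-bond acceptor, so this position is sensitive to ring composition alone, whereas the amino-group step a 1.4-fold higher number from compound 1 to compound 2 (0.14 log units; within the scatter) stays within the scatter. Nothing at hand accounts for the size of this step.

Still open, on these data alone, is whether the step depends on the amino group, as the pyridine ring appears here only with (cyclopropylmethyl)(propyl)amino and not with the butyl(ethyl)amino group of compound 1. Also open, as far as these compounds go, is how this ring position responds to other replacements, such as a 2,4,6-trimethylpyrimidin-5-yl ring or a methoxy group in place of one of the ring methyl groups.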